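Swapping the side chain on a sulfamoyl adenosine core

This account rests on a few compounds, and the source may have more. Where it says the series, first, only, none or still open, it means among the compounds named here.

Measured so far:
- compound 1, `CC[C@H](C)[C@H](N)C(=O)NS(=O)(=O)OC[C@H]1O[C@@H](n2cnc3c(N)ncnc32)[C@H](O)[C@@H]1O`, in a functional assay on PBMC cells (Homo sapiens) for inhibition (a higher number here means a weaker inhibitor, a lower number a stronger inhibitor), compound 1 gives 5600 nM
- compound 2, `CSCC[C@H](N)C(=O)NS(=O)(=O)OC[C@H]1OC[C@@H](n2cnc3c(N)ncnc32)C[C@@H]1O`, in this assay compound 2 gives 5500 nM

Among the measured compounds shown here, compound 1 and compound 2 differ in more than one place, so no single step between them is isolated; their two numbers lie within the usual scatter of each other, and compound 1 stands on a par with the only other measured compound. The unmeasured compound 3, `CSCC[C@H](N)C(=O)NS(=O)(=O)OC[C@H]1O[C@@H](n2cnc3c(N)ncnc32)[C@H](O)[C@@H]1O`, keeps the core of compound 1 and changes one thing: 2-(methylsulfanyl)ethyl in place of sec-butyl on a saturated chain carbon bound to an amine nitrogen and a carbonyl carbon. Compound 2 carries the same 2-(methylsulfanyl)ethyl group on a different core. For the measured compounds named here, no measured pair shows this change alone, so the step from compound 1 to compound 3 is expected to be small, with no clear direction beyond the scatter: a 1.1-fold lower number from compound 1 to compound 3 (0.05 log units; within the scatter). For compound 3 in this assay the estimate is 5000 nM, within 1500 nM to 16000 nM.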

Compound 3, half-maximal inhibitory concentration: 500 nM
Beside the measured number, compound 3's estimate is 10-fold (1.00 log units) above it; measured number outside the range, below it.
By their numbers in this assay, from the lowest: compound 3; then compounds 2 and 1 (each within the scatter of the next).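

With the core of compound 1 held fixed, placing 2-(methylsulfanyl)ethyl in place of sec-butyl on a saturated chain carbon bound to an amine nitrogen and a carbonyl carbon gives an 11-fold lower number from compound 1 to compound 3 (1.05 log units; beyond the scatter) in this assay. This shows that the group at this position matters a great deal, even though both groups have 4 heavy atoms and neither contains a ring. The earlier pair could not show this, since compound 1 and compound 2 differ in more than one place.

From the compounds shown here alone, it remains open whether a plain butyl chain, with carbon where the sulfur stands, or a longer chain carrying the same sulfur would give a similar number on this core. Nothing available gives a reason for the size of this step.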